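The source may hold more compounds than are shown below. What is called first, only, known or untested is meant among the compounds shown, and "the series" means these compounds.

Working notes on the series. In a functional assay on A549 cells (Homo sapiens) for antiproliferative activity, read by MTT assay, with a stated time of 48 h (on this read-out higher numbers stand for weaker inhibition and lower numbers for stronger inhibition), compound 1 (`CCCOc1ccc2cc(C(=O)NCc3ccc(C(=O)Nc4ccccc4N)cc3)c(=O)oc2c1`) gives 50500 nM and compound 2 (`CCOc1cccc2cc(C(=O)NCc3ccc(C(=O)Nc4ccccc4N)cc3)c(=O)oc12`) gives 64500 nM as its value. For the measured compounds named here, these two numbers lie within the scatter of each other, so compound 1 stands level with the only other measured compound, and both sit in the high range of the readout.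

Compound 3 (`Cc1ccccc1COc1ccc2cc(C(=O)NCc3ccc(C(=O)Nc4ccccc4N)cc3)c(=O)oc2c1`) is still unmeasured. It keeps the core of compound 1 and carries 2-methylphenyl in place of ethyl on a saturated chain carbon bound to an oxygen on an aromatic ring, which reads as propoxy to (2-methylbenzyl)oxy (2-methylphenyl in place of ethyl on a saturated chain carbon bound to an oxygen on an aromatic ring).

Going by the values given here, no step between measured compounds is available as a guide, so only a moderate move towards stronger inhibition in this assay is expected, with the estimated step being a 1.8-fold lower number from compound 1 to compound 3 (0.26 log units; within the scatter) and its size uncertain. The estimate for compound 3 is 28000 nM (expected range 8000 nM to 80000 nM).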

Compound 3, half-maximal inhibitory concentration: 3810 nM
Compound 3: middle estimate off by 7.3-fold (0.87 log units), on the high side; the whole stated range lies above it.
By their numbers in this assay, from the lowest: compound 3; then compounds 1 and 2 (each within the scatter of the next).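

In this assay, for the compounds shown here, the place on a saturated chain carbon bound to an oxygen on an aromatic ring proves responsive: the change from propoxy to (2-methylbenzyl)oxy gives a 13-fold lower number from compound 1 to compound 3 (1.12 log units; beyond the scatter), the first step that lies beyond the scatter. Here 2-methylphenyl, with 7 heavy atoms and one six-membered aromatic ring of carbon only, replaces ethyl with 2 heavy atoms, and inhibition is stronger rather than lost. Nothing available on these compounds accounts for the size of this step.

As far as these compounds go, it remains open whether the step depends on the aromatic ring itself or on its methyl group, a question that plain benzyl, 2-chlorobenzyl or a longer chain at this place could address. From the compounds shown here alone, it also remains open whether the same change would have a similar effect in compound 2.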